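Chain variation on the acid-bearing ring of the shared core

The source may report more compounds than this note shows. Statements on the series, on what has been measured and on what is new or still open speak of the compounds shown alone.

Measured compounds:
compound 1 `CCc1cc(-c2ccc(F)cc2)c(O)cc1OCCCOc1cccc(CCCCC(=O)N(C)C)c1CCC(=O)O` — 8.6 nM
compound 2 `CCc1cc(-c2ccc(F)cc2)c(O)cc1OCCCOc1ccccc1CCC(=O)O` — 3.8 nM

For the measured compounds named here, in an assay on membranes from lung (Cavia porcellus) for binding affinity to leukotriene B4 receptor (Homo sapiens), read by radioligand binding (on this read-out lower numbers stand for stronger inhibition and higher numbers for weaker inhibition), compound 2 has the lowest number of the two; its only neighbour is compound 1, and the step of a 2.3-fold lower number from compound 1 to compound 2 (0.35 log units; beyond the scatter) is modest but beyond the scatter. Compound 3 `CCc1cc(-c2ccc(F)cc2)c(O)cc1OCCCOc1cccc(CCCCC(=O)O)c1CCC(=O)O` has not yet been measured. It differs from compound 2 by 4-carboxybutyl in place of hydrogen on an aromatic carbon. Going by the values given here, the one step that bears on this change is a 2.3-fold lower number from compound 1 to compound 2 (0.35 log units; beyond the scatter), in which removing a substituent from an aromatic carbon of the core gave a modestly lower number. Returning a chain of similar length, now ending in a carboxylic acid, to an aromatic carbon is therefore expected to move the number back up by a modest amount, roughly reversing that step, though a carboxylic acid may behave differently from the amide. The expected step is a 1.7-fold higher number from compound 2 to compound 3 (0.23 log units; within the scatter). For compound 3 the estimate in this assay is 6.5 nM, with a range from 2.5 nM to 17 nM.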

Compound 3, inhibition constant: 0.71 nM
Compound 3: middle estimate off by 9.2-fold (0.96 log units), on the high side, outside the stated range (below it).
By their numbers in this assay, from the lowest: compound 3; then compound 2; then compound 1.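

In this assay, this aromatic carbon, ortho to a 2-carboxyethyl group, accepts a chain with a gain rather than a loss: 4-carboxybutyl in place of hydrogen gives a 5.4-fold lower number from compound 2 to compound 3 (0.73 log units; beyond the scatter) and so runs against the earlier step, a 2.3-fold lower number from compound 1 to compound 2 (0.35 log units; beyond the scatter), in which dropping the amide chain lowered the number. The chain end decides the direction, since hydroxy in place of dimethylamino on a carbonyl carbon gives a 12-fold lower number from compound 1 to compound 3 (1.08 log units; beyond the scatter) and the cost of a chain here holds for compound 1 but not for compound 3. Nothing at hand explains the effect of the terminal carboxylic acid.

Open, on these data alone, is whether a shorter or longer chain ending in a carboxylic acid keeps this gain. Also open, as far as these compounds go, is whether a primary amide, an ester or a tetrazole at the chain end would behave like the acid or like the dimethylamide.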